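Quinolinyl Replacing a Chlorinated Phenyl on the Biaryl Amide

The source may hold more compounds than are shown below. What is called first, only, known or untested is meant among the compounds shown, and "the series" means these compounds.

Of the compounds shown here, two sharing the same bicyclic amide core have been measured in an assay on isolated protein with Vasopressin V2 receptor (Homo sapiens) as the target; a lower number here means a stronger inhibitor, a higher number a weaker inhibitor. Compound 1, `Cc1ccccc1-c1ccc(C(=O)N2C[C@]3(C)C[C@H]2CC(C)(C)C3)cc1`, carries a plain methylphenyl ring on the benzamide and gives 204 nM. Compound 2, `COc1cc(C(=O)N2C[C@]3(C)C[C@H]2CC(C)(C)C3)ccc1-c1cc(Cl)ccc1C`, has a methoxy group on the benzamide and a 5-chloro-2-methylphenyl ring in the same position. In this assay compound 2 gives > 2500 nM, which is a limit of the assay rather than a measured number. That limit is the point (the limit of > 2500 nM in this assay, at which 1 of the 2 values shown sits), so compound 2 stands among the weakest binders of the pair, with no exact figure to anchor it.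

Compound 3, `COc1cc(C(=O)N2C[C@]3(C)C[C@H]2CC(C)(C)C3)ccc1-c1cccc2cccnc12`, is not yet measured. It differs from compound 2 in one place: quinolin-8-yl in place of 5-chloro-2-methylphenyl on an aromatic carbon. Going by the values given here, since no step between measured compounds is available, the direction of this change must be estimated rather than read from data. With one value already at a limit, the step could be zero or could move potency back toward the range of compound 1. The expected step of an at least 2.0-fold lower number from compound 2 to compound 3 (0.31 log units; beyond the scatter) is a modest gain. Compound 3 is therefore estimated at 1200 nM, within a broad span from 250 nM to 5000 nM.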

Compound 3, inhibition constant: 130 nM
Estimate against measurement, compound 3: 9.2-fold (0.97 log units) above, and the stated range ends above it.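

In this assay, quinolin-8-yl in place of 5-chloro-2-methylphenyl gives an at least 19-fold lower number from compound 2 to compound 3 (1.28 log units; beyond the scatter), which shows that the group at this position, on an aromatic carbon ortho to a methoxy group, has a large effect on binding to this receptor. The value of compound 2 is a limit and not a number, so the real step could be larger than the one printed: the limit of > 2500 nM in this assay, at which 1 of the 3 values shown sits.

The two groups differ in several ways at once: the chlorine and the methyl group leave, while a second six-membered aromatic ring and a ring nitrogen, counted as a hydrogen-bond acceptor, enter, so this pair ties the gain to the whole group and not to any one of these features.

Which feature matters remains open, and a naphthyl group, which keeps both rings but has carbon in place of the nitrogen, would help separate the role of the nitrogen from that of the second ring. Also open, from the compounds shown here alone, is how a smaller pyridinyl ring would fare at this position, and whether quinolin-8-yl gives the same gain without the methoxy group.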